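Trimethoxyphenyl series: pyrazole replaced by vinyl on the aryl ring

A few compounds are considered here, and "the series" means these few. Any claim that something is new, unique, unknown or untested is made for them only; others in the source may bear on it.

Measured compounds:
- compound 1 `COc1cc(-c2ccnc3cc(-c4ccc(-c5cnn(C)c5)cc4)nn23)cc(OC)c1OC` gives 1830 nM
- compound 2 `COc1cc(-c2ccnc3cc(-c4cn(CO)c5ccccc45)nn23)cc(OC)c1OC` gives 103 nM

Both values come from a functional assay on HeLa cells (Homo sapiens) for inhibition, read by CCK-8 assay, with a stated time of 48 h; on this read-out higher numbers stand for weaker inhibition and lower numbers for stronger inhibition. On these two numbers compound 1 stands highest; compound 2, which carries a different aryl group on the shared core, gives the lower number, and the gap between the two lies beyond the scatter.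

Compound 3 `C=Cc1ccc(-c2cc3nccc(-c4cc(OC)c(OC)c(OC)c4)n3n2)cc1` keeps the core of compound 1 and differs in one place: vinyl in place of 1-methyl-1H-pyrazol-4-yl on an aromatic carbon. Among the measured compounds shown here, no measured pair shows this change, so its effect cannot be read from the data. For the measured compounds named here, compound 2 shows only that another aryl group at this position can give a markedly lower number. For compound 3 the step of a 1.6-fold higher number from compound 1 to compound 3 (0.21 log units; within the scatter) is expected to be small, toward weaker inhibition, and quite possibly within the scatter. Compound 3 is estimated at 3000 nM, within the range 800 nM to 12000 nM.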

Compound 3, half-maximal inhibitory concentration: 882 nM
Compound 3: the middle estimate sits 3.4-fold (0.53 log units) above what was measured; measured number inside the range.
By their numbers in this assay, from the lowest: compound 2; then compound 3; then compound 1.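

In this assay, among the compounds shown here, the change from 1-methyl-1H-pyrazol-4-yl to vinyl gives a 2.1-fold lower number from compound 1 to compound 3 (0.32 log units; beyond the scatter) and is the first single change measured at this place on the six-membered aromatic ring of carbon only. The step is modest but beyond the scatter, so the five-membered aromatic ring with its two hetero atoms is not needed to keep inhibition at this level, and vinyl, with no ring and no hydrogen-bond acceptors, does slightly better. Nothing at hand explains this step.

Still open, going by these compounds, is whether the double bond of vinyl matters, which ethyl at the same place would test. Also open, on these data alone, is how an amine, a carboxylic acid or a longer chain such as butyl would move the number on this aromatic carbon.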